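Trading a Benzyl Group for a Small Cyclopropyl Ring

A few compounds are considered here, and "the series" means these few. Any claim that something is new, unique, unknown or untested is made for them only; others in the source may bear on it.

Three compounds share one core and differ in a single group attached to it. Compound 1 `O=C(O)c1ccccc1-c1ccc(CCc2ncc(-c3ccccc3)[nH]2)cc1` gives 4950 nM in an in vitro functional assay on cells for agonist activity at Bombesin receptor subtype-3 (Homo sapiens), read by luminescence and calcium flux; a lower number here means that less compound is needed, a higher number that more compound is needed for the effect. Compound 2 `COc1ccc(Cc2cnc(CCc3ccc(-c4ccccc4C(=O)O)cc3)[nH]2)cc1` gives 5360 nM in this assay, and the step of a 1.1-fold higher number from compound 1 to compound 2 (0.03 log units; within the scatter) stays within the scatter. Compound 3 `O=C(O)c1ccccc1-c1ccc(CCc2ncc(CCc3ccccc3)[nH]2)cc1` gives 1320 nM, the lowest number of the three, reached through the steps of a 3.8-fold lower number from compound 1 to compound 3 (0.57 log units; beyond the scatter) and a 4.1-fold lower number from compound 2 to compound 3 (0.61 log units; beyond the scatter). Compound 4 `O=C(O)c1ccccc1-c1ccc(CCc2ncc(CC3CC3)[nH]2)cc1` has not yet been measured; it differs from compound 3 in one place: cyclopropyl in place of benzyl on a saturated chain carbon bound to an aromatic carbon. Cut one bond further out, the same difference reads phenethyl to cyclopropylmethyl. Both measured steps into compound 3 altered the group at this same position and each lowered the number by a modest step, yet neither of them removed the six-membered aromatic ring of carbon only from the chain, so the measured data show only that this position can shift the number modestly, not in which direction a much smaller ring will push it. For compound 4 the number is expected to rise again, a step of a 2.7-fold higher number from compound 3 to compound 4 (0.42 log units; beyond the scatter), giving an estimate of 3500 nM with a range from 1000 nM to 12000 nM.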

Compound 4, half-maximal effective concentration: 1000 nM
For compound 4 the middle estimate is 3.5-fold (0.54 log units) above the measured one; the measured number falls inside the stated range.
By their numbers in this assay, from the lowest: compounds 4 and 3 (each within the scatter of the next); then compounds 1 and 2 (each within the scatter of the next).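

With benzyl replaced by cyclopropyl, the group at this position shrinks from 7 heavy atoms to 3 and loses its six-membered aromatic ring of carbon only, yet this assay shows only a 1.3-fold lower number from compound 3 to compound 4 (0.12 log units; within the scatter), so that aromatic ring is not required to reach this level. The lower numbers seen against the other two compounds also remain, with a 5.4-fold lower number from compound 2 to compound 4 (0.73 log units; beyond the scatter) and a 5.0-fold lower number from compound 1 to compound 4 (0.69 log units; beyond the scatter). Nothing available explains why these two different groups give matching results.

As far as these compounds go, whether any ring is needed here remains open, and an open butyl chain on the saturated chain carbon bound to an aromatic carbon would address that. From the compounds shown here alone, the effect of an amine at this position also remains unknown.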